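A few compounds are considered here, and "the series" means these few. Any claim that something is new, unique, unknown or untested is made for them only; others in the source may bear on it.

Compound 1 `CCCCCOC(=O)N1CCN(C(=O)[C@H](CCC(=O)O)NC(=O)c2cc(N3CCC(C(=O)NCC)CC3)nc(-c3ccccc3)n2)CC1`, in an in vivo ADME assay on the whole organism (strain Sprague-Dawley) for pharmacokinetics, with Rattus norvegicus as the target, at a dose of 5 mg/kg by the oral route (on this read-out lower numbers stand for lower oral bioavailability and higher numbers for higher oral bioavailability), compound 1 gives 8%.
Compound 2 `CCCCCOC(=O)N1CCN(C(=O)[C@H](CCC(=O)O)NC(=O)c2cc(N3CCC(COC)CC3)nc(-c3ccccc3)n2)CC1`, in this assay compound 2 gives 61%.

Compound 2 stands higher of the two, the step of a number 53 percentage points higher from compound 1 to compound 2 (beyond the scatter) lying beyond the scatter. Compound 3 `CCCCCOC(=O)N1CCN(C(=O)[C@H](CCC(=O)O)NC(=O)c2cc(N3CCC(C(=O)N4CCCC4)CC3)nc(-c3ccccc3)n2)CC1` differs from compound 2 by (pyrrolidin-1-yl)carbonyl in place of methoxymethyl on a saturated ring carbon. Going by the values given here, the one step that bears on it, a number 53 percentage points higher from compound 1 to compound 2 (beyond the scatter), ran from an amide to methoxymethyl; compound 3 returns to an amide, so a step back downward is expected, a number 41 percentage points lower from compound 2 to compound 3 (beyond the scatter). Compound 3 is therefore estimated at 20%, expected between 5% and 45%.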

Compound 3, oral bioavailability: 13%
For compound 3 the middle estimate is 7 percentage points above the measured one; the range from low to high includes it.
By their numbers in this assay, from the lowest: compounds 1 and 3 (each within the scatter of the next); then compound 2.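

In this assay, the move to (pyrrolidin-1-yl)carbonyl on this saturated ring carbon gives a number 48 percentage points lower from compound 2 to compound 3 (beyond the scatter) and so takes back the gain seen with methoxymethyl. Changing the amide itself, with pyrrolidin-1-yl in place of ethylamino on the carbonyl carbon, gives a number 5 percentage points higher from compound 1 to compound 3 (within the scatter) and leaves the two amides within the scatter of each other. Among these three compounds, then, both carbonyl-linked groups stand low, and only the methoxymethyl ether stands high. Going by these compounds, whether hydroxymethyl, ethoxymethyl or an amine such as aminomethyl at this carbon would keep the higher oral bioavailability stays open. Nothing given here accounts for the difference between the ether and the amides.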